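The source may hold more compounds than are shown below. What is called first, only, known or untested is meant among the compounds shown, and "the series" means these compounds.

Of the compounds shown here, three of one series have been measured in an assay on HL-60 cells for agonist activity at vitamin D3 receptor (Homo sapiens), read by microscopy, with a stated time of 96 h; a higher number here means that more compound is needed for the effect, a lower number that less compound is needed. Compound 1 `CCn1c(C(=O)N(CCC#N)CCC#N)ccc1C(CC)(CC)c1ccc(OCC(=O)C(C)(C)C)c(C)c1` gives 870 nM. Compound 2 `CC[C@@H](C)[C@H](NC(=O)c1ccc(C(CC)(CC)c2ccc(OCC(O)C(C)(C)C)c(C)c2)n1CC)C(=O)OC` gives 26 nM. For the measured compounds named here, compound 3 `CCn1c(C(=O)NCCN)ccc1C(CC)(CC)c1ccc(OCC(O)C(C)(C)C)c(C)c1` gives 10 nM, the lowest of the three numbers; the only single-point step among them, a 2.6-fold lower number from compound 2 to compound 3 (0.41 log units; beyond the scatter), is modest but beyond the scatter, while compound 1 lies far higher.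

Compound 4 `CCn1c(C(=O)N(CCC#N)CCC#N)ccc1C(CC)(CC)c1ccc(OCC(O)C(C)(C)C)c(C)c1` has not yet been measured. It differs from compound 3 at the carbonyl carbon: a group of 9 heavy atoms (6 carbon, 3 nitrogen; no ring) in place of a group of 4 heavy atoms (2 carbon, 2 nitrogen; no ring), on a carbonyl carbon. Going by the values given here, no measured step isolates this exact exchange, so its size cannot be read off directly. The nearest evidence is that compound 1 also carries this nine-atom group on its amide nitrogen and gives 870 nM, whereas compounds 2 and 3, with other groups on that nitrogen, sit much lower. Compound 4 is therefore expected to move upward, with a step of roughly a 30-fold higher number from compound 3 to compound 4 (1.48 log units; beyond the scatter) in this assay. The estimate for compound 4 is 300 nM, with a likely range from 60 nM to 1500 nM.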

Compound 4, half-maximal effective concentration: 97 nM
Estimate against measurement, compound 4: 3.1-fold (0.49 log units) above; low and high end bracket the measured number.
By their numbers in this assay, from the lowest: compound 3; then compound 2; then compound 4; then compound 1.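

Exchanging (tert-butyl)carbonyl for 1-hydroxy-2,2-dimethylpropyl while the group on the carbonyl carbon stays the same gives a 9.0-fold lower number from compound 1 to compound 4 (0.95 log units; beyond the scatter) in this assay, so that group alone does not set the high number of compound 1. With 1-hydroxy-2,2-dimethylpropyl held in place, the group of 9 heavy atoms on the carbonyl carbon gives a 9.7-fold higher number from compound 3 to compound 4 (0.99 log units; beyond the scatter) against (2-aminoethyl)amino, and a 3.7-fold higher number from compound 2 to compound 4 (0.57 log units; beyond the scatter) against the group of 10 heavy atoms, so changes at this position and at the side chain each move the number. No measurement shown here offers an explanation for these steps.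

Going by these compounds, whether the exchange of (tert-butyl)carbonyl for 1-hydroxy-2,2-dimethylpropyl keeps its size with (2-aminoethyl)amino on the carbonyl carbon remains open. So does how a longer chain ending in an amine, or a carboxylic acid, would behave at that position.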